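The source may hold more compounds than are shown below. What is called first, only, known or untested is meant among the compounds shown, and "the series" means these compounds.

Compound 1 `O=C1Nc2ccc(F)cc2/C1=C\C(=O)c1ccc[nH]1` gives 2840 nM
Compound 2 `CN1CCN(c2cccc(N/C=C3\C(=O)Nc4ccc(NC(=O)c5c(F)cccc5F)cc43)c2)CC1` gives 1630 nM

In a functional assay on NCI-H1650 cells (Homo sapiens) for inhibition, read by sulforhodamine B assay, with a stated time of 3 days (on this read-out lower numbers stand for stronger inhibition and higher numbers for weaker inhibition), compound 2 stands within the usual scatter of compound 1, so these two values set no order between them. For the measured compounds named here, no two measured compounds differ in one place only, so no single structural change has yet been tested.

Compound 3 `CC(C)CC(=O)Nc1ccc2c(c1)/C(=C/Nc1cccc(N3CCN(C)CC3)c1)C(=O)N2` keeps the rest of compound 2 but has isobutyl in place of 2,6-difluorophenyl on a carbonyl carbon. Going by the values given here, with no measured step to guide the call, only a small shift in this assay is expected, no larger than the scatter, with a slight lean towards weaker inhibition. The estimate starts from compound 2 at 1630 nM. The expected change is a 1.2-fold higher number from compound 2 to compound 3 (0.09 log units; within the scatter). For compound 3 the estimated value is 2000 nM, with an expected range of 650 nM to 6000 nM.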

Compound 3, half-maximal inhibitory concentration: 5870 nM
Beside the measured number, compound 3's estimate is 2.9-fold (0.47 log units) below it; the measured number falls inside the stated range.
By their numbers in this assay, from the lowest: compounds 2 and 1 (each within the scatter of the next); then compound 3.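

For the compounds shown here, this is the first change that can be read at a single place: in this assay, isobutyl in place of 2,6-difluorophenyl on a carbonyl carbon gives a 3.6-fold higher number from compound 2 to compound 3 (0.56 log units; beyond the scatter), a modest step beyond the scatter. The group on this carbonyl carbon therefore matters for inhibition here, and in this one pair the weaker inhibition comes with the loss of the aromatic ring and its two fluorines. Nothing measured on these compounds explains the step.

Going by these compounds, one pair cannot separate the contribution of the ring from that of the fluorines, and it remains open how an unsubstituted phenyl or a cyclohexyl on this carbonyl carbon would compare. On these data alone, it is also open whether a chain ending in an amine would behave like isobutyl.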